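The compounds below may be only part of what the source reports. "The series", "measured", "known", "first", "only" and "open" are said of these compounds alone.

Of the compounds shown here, three of one series have been measured in a functional assay on PC-3 cells (Homo sapiens) for inhibition, read by sulforhodamine B assay; on this read-out higher numbers stand for weaker inhibition of growth and lower numbers for stronger inhibition of growth. Compound 1 `c1ccc(-c2ccc(-c3ccc(-c4nc5ccccc5[nH]4)cc3)cc2)cc1` gives 41200 nM. In this assay compound 3 `COc1ccc(-c2ccc(-c3ccc(-c4nc5ccccc5[nH]4)cc3)cc2)cc1OC` gives 47100 nM. Compound 2 `COc1ccc(-c2ccc(-c3ccc(-c4nc5cc(C)ccc5[nH]4)cc3)cc2)cc1OC` gives 2560 nM in this assay, the lowest of the three numbers, and its steps to the other two are both beyond the scatter. Compound 1 differs from compound 3 by phenyl in place of 3,4-dimethoxyphenyl on an aromatic carbon, and the step reads a 1.1-fold lower number from compound 3 to compound 1 (0.06 log units; within the scatter). The core of compound 2 differs from the core of compound 3 by methyl in place of hydrogen on an aromatic carbon; that step is an 18-fold higher number from compound 2 to compound 3 (1.26 log units; beyond the scatter), a large one. Compound 4 `Cc1ccc2[nH]c(-c3ccc(-c4ccc(-c5ccccc5)cc4)cc3)nc2c1` has not yet been measured. It differs from compound 2 by phenyl in place of 3,4-dimethoxyphenyl on an aromatic carbon, the same change that leads from compound 3 to compound 1, now made on the core of compound 2. Because the earlier step of a 1.1-fold lower number from compound 3 to compound 1 (0.06 log units; within the scatter) lay within the scatter, a step of similar size is expected here, a 1.1-fold lower number from compound 2 to compound 4 (0.05 log units; within the scatter). That expectation rests on a single earlier pair. For compound 4 in this assay the estimate is 2300 nM, with a range from 1000 nM to 6000 nM.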

Compound 4, concentration for 50% growth inhibition: 100000 nM
The estimate for compound 4 lay 43-fold (1.64 log units) below the measured number; measured number outside the range, above it.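

In this assay the replacement of 3,4-dimethoxyphenyl by phenyl on the methyl-bearing core gave a 39-fold higher number from compound 2 to compound 4 (1.59 log units; beyond the scatter), so the change did not carry over from one core to the other: the same change on two cores in this assay, a 1.1-fold lower number (0.06 log units; within the scatter) from compound 3 to compound 1 and a 39-fold higher number (1.59 log units; beyond the scatter) from compound 2 to compound 4, 45-fold (1.65 log units) apart, beyond the scatter of two such steps

The methyl group likewise gave a different result with phenyl in the molecule, a 2.4-fold higher number from compound 1 to compound 4 (0.39 log units; beyond the scatter), and so the two changes cannot be treated as independent in this set: the same change on two cores in this assay, an 18-fold higher number (1.26 log units; beyond the scatter) from compound 2 to compound 3 and a 2.4-fold lower number (0.39 log units; beyond the scatter) from compound 4 to compound 1, 45-fold (1.65 log units) apart, beyond the scatter of two such steps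

Among these four compounds, the lowest number occurs only where methyl and 3,4-dimethoxyphenyl stand together, in compound 2, but one set of four compounds does not show why or whether the same holds on any other core.

The compounds shown leave open whether a single methoxy group would be enough to keep the low number of compound 2, or whether an amine or a carboxylic acid in place of 3,4-dimethoxyphenyl would do so. They also leave open whether ethyl or chlorine in place of the methyl would show the same dependence on the other group.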